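Sulfamoyl to methylsulfonyl: expected size of the step

This account rests on a few compounds, and the source may have more. Where it says the series, first, only, none or still open, it means among the compounds named here.

Measured so far:
compound 1 `COc1ccc(S(N)(=O)=O)cc1C(=O)Nc1cccc(-c2nncn2C(C)C)n1` gives 1%
compound 2 `COc1cc(C)c(S(N)(=O)=O)cc1C(=O)Nc1cccc(-c2nncn2C(C)C)n1` gives 7%

Both numbers come from an assay for inhibition of myosin light chain kinase 2, skeletal/cardiac muscle (Homo sapiens), tested at 1 uM; on this read-out lower numbers stand for less inhibition and higher numbers for more inhibition at the one concentration tested (going by the name of the read-out). Compound 1 stands lowest of the two on this read-out, and its nearest neighbour, compound 2, differs from it by a number 6 percentage points higher from compound 1 to compound 2 (within the scatter), a change of methyl in place of hydrogen on an aromatic carbon. Both compounds show little inhibition at the single concentration tested.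

Compound 3 `COc1ccc(S(C)(=O)=O)cc1C(=O)Nc1cccc(-c2nncn2C(C)C)n1` has not yet been measured. It differs from compound 1 by methyl in place of amino on a sulfonyl sulfur.

For the measured compounds named here, no measured step touches the sulfonyl sulfur; the only step in hand, from compound 1 to compound 2, lies within the scatter and concerns a different part of the molecule. The expectation for compound 3 therefore rests on the low level of both measured compounds and on the absence of any evidence that the sulfonyl substituent moves this read-out.

Compound 3 is expected to give 3%, within -8% to 15%.

The estimated step is a number 2 percentage points higher from compound 1 to compound 3 (within the scatter), which is expected to lie within the scatter.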

Compound 3, a percentage reported as inhibition, at one concentration (the size of the read-out at that concentration, not a potency): 0%
For compound 3 the middle estimate is 3 percentage points above the measured one; low and high end bracket the measured number.
By their numbers in this assay, from the lowest: compounds 3, 1 and 2 (each within the scatter of the next).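

In this assay, for the compounds shown here, the change from sulfamoyl to methylsulfonyl gives a number 1 percentage points lower from compound 1 to compound 3 (within the scatter); this is the first reading at the sulfonyl sulfur, and it shows that methyl in place of amino, with the loss of the hydrogen-bond donor counted for the amino group, leaves no difference that can be told from scatter. The reading is limited by its starting point: compound 1 gives only 1% in this assay, so a loss of inhibition could hardly show, and the step establishes only that methylsulfonyl brings no inhibition beyond the scatter at the one concentration tested. Nothing available explains this reading at the sulfonyl sulfur.

Open, going by these compounds, is whether a longer chain such as ethyl, a dimethylamino group on the sulfonyl sulfur, or a carboxylic acid in place of the whole sulfonyl group would lift the read-out beyond the scatter. Also open, on these data alone, is whether methyl in place of amino reads the same on the core of compound 2, which carries the added aromatic methyl.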